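Trifluoroethoxy for methylsulfanyl on the fused ring

This account rests on a few compounds, and the source may have more. Where it says the series, first, only, none or still open, it means among the compounds named here.

Two compounds of the series carry numbers in an assay on isolated protein for inhibition of Ectonucleotide pyrophosphatase/phosphodiesterase family member 1 (Homo sapiens), tested at 10 uM; a lower number here means less inhibition, a higher number more inhibition at the concentration tested (going by the name of the read-out). Compound 1 `CC(=O)c1cccc(NC(=O)CSc2nc3cccnc3[nH]2)c1` gives 50%. Compound 2 `COc1ccc(NC(=O)CSc2nc3ccc(SC)nc3[nH]2)cc1OC` gives 59%, and the two values lie within the usual scatter of each other, so neither stands apart. Compound 3 `COc1ccc(NC(=O)CSc2nc3ccc(OCC(F)(F)F)nc3[nH]2)cc1OC` is not yet measured; it differs from compound 2 by 2,2,2-trifluoroethoxy in place of methylsulfanyl on an aromatic carbon. Going by the values given here, no step between measured compounds is available to lean on, so the expected step is small, not clearly beyond the scatter, in either direction: a number 4 percentage points lower from compound 2 to compound 3 (within the scatter). Compound 3 is estimated at 55%, within 30% to 80%.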

Compound 3, a percentage reported as inhibition, at one concentration (the size of the read-out at that concentration, not a potency): 61%
Estimate against measurement, compound 3: 6 percentage points below; the measured number falls inside the stated range.
By their numbers in this assay, from the lowest: compounds 1, 2 and 3 (each within the scatter of the next, the first and the last beyond it).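

In this assay, going by these compounds alone, replacing methylsulfanyl with 2,2,2-trifluoroethoxy on the aromatic carbon next to the ring nitrogen gives a number 2 percentage points higher from compound 2 to compound 3 (within the scatter) and provides the first one-place comparison. This position therefore accepts the group with more heavy atoms, with no change beyond the scatter. No evidence is available to explain this result.

Going by these compounds, it remains open what an amine or a carboxylic acid at this position would give. On these data alone, because both numbers come from a single concentration, any potency difference between these two compounds also remains open.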